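The source may hold more compounds than are shown below. What is called first, only, known or untested is meant among the compounds shown, and "the series" means these compounds.

In an ADME assay on CCRF-HSB-2 cells (Homo sapiens) for cytotoxicity, with a stated time of 7 days (a lower number here means that less compound is tolerated, a higher number that more compound is tolerated), compound 3 `CCCOc1nc(N)nc2c1ncn2/C=C1/CC1(CO)CO` stands only at a limit, > 20000 nM. Compound 2 `Nc1nc(NC2CCCCC2)c2ncn(/C=C3/CC3(CO)CO)c2n1` is likewise reported only as a limit, > 20000 nM. Among the measured compounds shown here, compound 1 `CC(C)CSc1nc(N)nc2c1ncn2/C=C1/CC1(CO)CO` gives the sole actual number, 60000 nM. Compound 4 `Nc1nc(SC2CCCC2)c2ncn(/C=C3/CC3(CO)CO)c2n1` differs from compound 3 by cyclopentylsulfanyl in place of propoxy on an aromatic carbon. The measured steps supply no size: a step that the limit leaves unreadable from compound 1 to compound 3, a step that the limit leaves unreadable from compound 1 to compound 2 and a step that the two limits leave unreadable from compound 2 to compound 3. They therefore support no expected direction in this assay. For the measured compounds named here, the only guide is compound 1, the other sulfanyl compound, at 60000 nM. The expected step is a step that the limit leaves unreadable from compound 3 to compound 4, and its size stays uncertain. Compound 4 is estimated at 40000 nM, with an expected range of 10000 nM to 100000 nM.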

Compound 4, half-maximal cytotoxic concentration: 91000 nM
Estimate against measurement, compound 4: 2.3-fold (0.36 log units) below, within the range that was stated.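

In this assay, among the compounds shown here, the change on the sulfur gives the first readable step at this position: a 1.5-fold higher number from compound 1 to compound 4 (0.18 log units; within the scatter). Between these two sulfanyl compounds, a five-membered ring of carbon in place of the open isobutyl chain therefore leaves the read-out within the scatter. The steps to compound 2 and compound 3 cannot be read because those values are limits, not numbers: the limit of > 20000 nM in this assay, at which 2 of the 4 values shown sit.

Going by these compounds, whether the propoxy and cyclohexylamino compounds truly differ from the sulfanyl pair stays open. Also open, on these data alone, is how a benzyl group on the sulfur or a carboxylic acid on the chain would read here.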